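This account rests on a few compounds, and the source may have more. Where it says the series, first, only, none or still open, it means among the compounds named here.

In an assay on cells for inhibition of matrix metalloproteinase-9 (Homo sapiens), read by fluorescence, with stated times of 15 min and 4 h (a lower number here means a stronger inhibitor, a higher number a weaker inhibitor), compound 1 `Cc1ccc2nc(-c3cccc(NC(=O)CCc4ccccc4)c3)[nH]c2c1` gives 26600 nM. Its close relative compound 2 `O=C(CCc1ccccc1)Nc1cccc(-c2nc3ccc(Br)cc3[nH]2)c1` gives 14500 nM in this assay. The two differ by a single alteration, (methyl in place of bromo on an aromatic carbon), and the resulting step, a 1.8-fold higher number from compound 2 to compound 1 (0.26 log units; within the scatter), shows that swapping these two small groups on the shared core leaves the potency essentially unchanged.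

Compound 3 `O=[N+]([O-])c1cccc(-c2nc3ccc(Br)cc3[nH]2)c1` carries a nitro group in place of the amide-bearing chain of compound 2, and the difference between the two cores is not broken down here. For compound 3 this assay reports > 100000 nM, which is only a limit, (the limit of > 100000 nM in this assay, at which 1 of the 3 values shown sits), rather than a number, so its potency is known only to lie at or beyond that boundary.

Compound 4 `Cc1ccc2nc(-c3cccc([N+](=O)[O-])c3)[nH]c2c1` has not yet been measured. It stands to compound 3 exactly as compound 1 stands to compound 2: the change is methyl in place of bromo on an aromatic carbon, and it is the same change made on the same place of the same core. For compound 4 the expected step is a step that the limit leaves unreadable from compound 3 to compound 4, because a 1.8-fold higher number from compound 2 to compound 1 (0.26 log units; within the scatter) is within the scatter and gives no reason to expect the methyl-for-bromo swap to move the reading noticeably. Since compound 3 already sits at the limit, compound 4 is estimated to come in near 150000 nM, with a plausible range from 60000 nM to 400000 nM, and it is expected that this assay most likely returns a limit rather than a number for compound 4.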

Compound 4, half-maximal inhibitory concentration: 36600 nM
Compound 4: middle estimate off by 4.1-fold (0.61 log units), on the high side, and the stated range ends above it.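

On the core carrying the nitro group, methyl in place of bromo on an aromatic carbon gives an at least 2.7-fold lower number from compound 3 to compound 4 (0.43 log units; beyond the scatter), whereas on the core carrying the amide-bearing chain the same change gives a 1.8-fold higher number from compound 2 to compound 1 (0.26 log units; within the scatter). The swap therefore cannot be carried from one core to the other in this series with its size unchanged, and the two cores give different answers in this assay: the same change on two cores in this assay, a 1.8-fold higher number (0.26 log units; within the scatter) from compound 2 to compound 1 and an at least 2.7-fold lower number (0.43 log units; beyond the scatter) from compound 3 to compound 4, at least 5.0-fold (0.70 log units) apart, beyond the scatter of two such steps. Compound 3 reads > 100000 nM, which is a limit and not a number; the full size of the step on its core remains unknown, and nothing shown tells why the two cores differ.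

The two pairs leave open how the same swap behaves on any third core, such as one with an amine in place of the nitro group, and whether a chloro or an ethyl group in place of the methyl would give a similar step on either core. They also leave open whether a longer chain in place of the amide-bearing chain of compound 2 would change its reading in this assay, and in which direction.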